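Hydroxy to nitro swap on the enone aryl ring

The source may report more compounds than this note shows. Statements on the series, on what has been measured and on what is new or still open speak of the compounds shown alone.

Compound 1 `COc1ccc(C(=O)/C=C\Nc2ccc(-c3nc4cc(OC)c(OC)c(OC)c4s3)cc2C)cc1O` gives 15400 nM in a functional assay on MIA PaCa-2 cells (Homo sapiens) for antiproliferative activity, read by sulforhodamine B assay, with a stated time of 48 h; a lower number here means a stronger inhibitor, a higher number a weaker inhibitor. Compound 2 `COc1ccc(C(=O)/C=C\Nc2ccc(-c3nc4cc(OC)c(OC)c(OC)c4s3)cc2C)cc1[N+](=O)[O-]` carries the change nitro in place of hydroxy on an aromatic carbon and gives 23400 nM in this assay; the step is a 1.5-fold higher number from compound 1 to compound 2 (0.18 log units; within the scatter). Compound 3 `COc1ccc2nc(-c3ccc(N/C=C\C(=O)c4ccc(OC)c(O)c4)cc3)sc2c1` gives 21900 nM in this assay; the difference between the core of compound 3 and the core of compound 1 is not broken down here, and the values of compound 3 and compound 1 lie within the scatter of one another. Compound 4 `COc1ccc2nc(-c3ccc(N/C=C\C(=O)c4ccc(OC)c([N+](=O)[O-])c4)cc3)sc2c1`, not yet measured, differs from compound 3 by nitro in place of hydroxy on an aromatic carbon, the same change as from compound 1 to compound 2, at the same place. The expected step is a 1.5-fold higher number from compound 3 to compound 4 (0.18 log units; within the scatter), resting on the earlier step of a 1.5-fold higher number from compound 1 to compound 2 (0.18 log units; within the scatter). Compound 4 is thus estimated at 33000 nM in this assay, with a range from 15000 nM to 70000 nM.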

Compound 4, half-maximal inhibitory concentration: 23600 nM
The estimate for compound 4 lay 1.4-fold (0.15 log units) above the measured number, and the stated range covers the measured number.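

On the second core, nitro in place of hydroxy gives a 1.1-fold higher number from compound 3 to compound 4 (0.03 log units; within the scatter) in this assay. The step agrees with the one on the first core: the same change on two cores in this assay, a 1.5-fold higher number (0.18 log units; within the scatter) from compound 1 to compound 2 and a 1.1-fold higher number (0.03 log units; within the scatter) from compound 3 to compound 4, 1.4-fold (0.15 log units) apart, within the scatter of two such steps. This shows that on these two cores the swap of 3-hydroxy-4-methoxyphenyl to 4-methoxy-3-nitrophenyl leaves the number within the scatter, but it gives no measurable size for the step and does not show that the same would hold on any other core.

Still open, going by these compounds, is whether an amine or a carboxylic acid at this aromatic carbon would move the number beyond the scatter on either core. Also open, on these data alone, is whether a longer chain in place of the methoxy group would change how the swap reads.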